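The source may report more compounds than this note shows. Statements on the series, on what has been measured and on what is new or still open speak of the compounds shown alone.

Measured compounds:
- compound 1 `Cc1cc(C)cc(S(=O)(=O)c2c(C(=O)N[C@@H]3CCNC3)[nH]c3ccc(Cl)cc23)c1`: 37300 nM
- compound 2 `Cc1cc(C)cc(S(=O)(=O)c2c(C(=O)N[C@@H]3CCN(Cc4cccnc4)C3)[nH]c3ccc(Cl)cc23)c1`: 36500 nM
- compound 3 `Cc1cc(C)cc(S(=O)(=O)c2c(C(=O)N[C@H]3CCN(Cc4cccnc4)C3)[nH]c3ccc(Cl)cc23)c1`: 22800 nM

In an ADME assay on MT4 cells (Homo sapiens) for cytotoxicity, read by MTT assay, with a stated time of 5 days (a higher number here means that more compound is tolerated, a lower number that less compound is tolerated), compound 1 gives 37300 nM, the highest of the three numbers shown, though its steps to the others stay within the scatter: a 1.0-fold lower number from compound 1 to compound 2 (0.01 log units; within the scatter) and a 1.6-fold lower number from compound 1 to compound 3 (0.21 log units; within the scatter). Between compound 2 and compound 3 the step is a 1.6-fold lower number from compound 2 to compound 3 (0.20 log units; within the scatter), which is notable only for (the fact that compounds 2 and 3 differ only in the configuration as drawn). Compound 4 `Cc1cc(C)cc(S(=O)(=O)c2c(C(=O)NC3CN(CC(N)=O)C3)[nH]c3ccc(Cl)cc23)c1` departs from compound 1 by 1-(carbamoylmethyl)azetidin-3-yl in place of pyrrolidin-3-yl on an amide-type nitrogen. Within the data shown here, no measured step reworks the ring on the amide-type nitrogen itself; the nearest changes, substitution on the amine nitrogen in the ring, left the number essentially unmoved. Compound 4 is therefore expected to show no step beyond the scatter, a 1.2-fold lower number from compound 1 to compound 4 (0.07 log units; within the scatter). The estimate for compound 4 is 32000 nM, within the range 13000 nM to 75000 nM.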

Compound 4, half-maximal cytotoxic concentration: 25500 nM
Compound 4: middle estimate off by 1.3-fold (0.10 log units), on the high side, within the range that was stated.
By their numbers in this assay, from the lowest: compounds 3, 4, 2 and 1 (each within the scatter of the next).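

Setting 1-(carbamoylmethyl)azetidin-3-yl in place of pyrrolidin-3-yl on the amide-type nitrogen reworks the ring itself, yet this assay shows only a 1.5-fold lower number from compound 1 to compound 4 (0.17 log units; within the scatter) for this change. Against the 1-((pyridin-3-yl)methyl)pyrrolidin-3-yl compounds the readings are a 1.4-fold lower number from compound 2 to compound 4 (0.16 log units; within the scatter) and a 1.1-fold higher number from compound 3 to compound 4 (0.05 log units; within the scatter), so among these four compounds this position has taken a four-membered ring and a carbamoylmethyl group without a step beyond the scatter. Nothing shown here accounts for this. The compounds shown leave open whether a piperidine ring on the amide-type nitrogen, or a carboxylic acid on the ring nitrogen, would keep the number in this range.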